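Halogen swap on the aryl ketone of a pyrazole chalcone

The source may report more compounds than this note shows. Statements on the series, on what has been measured and on what is new or still open speak of the compounds shown alone.

Measured compounds:
Compound 1 `COc1ccc(-c2cc(/C=C/C(=O)c3ccc(N)cc3)[nH]n2)cc1` — in a functional assay on NCI-H23 cells (Homo sapiens) for cytotoxicity, read by sulforhodamine B assay, with a stated time of 48 h, tested at 0.1 uM (a lower number here means a stronger effect, a higher number a weaker effect of the compound at the concentration tested), compound 1 gives 94%
Compound 2 `COc1cc(-c2cc(/C=C/C(=O)c3ccc(Cl)c(Cl)c3)[nH]n2)cc(OC)c1OC` — in this assay compound 2 gives 92%

Compound 2 has the lower of the two numbers, but its nearest neighbour, compound 1, stands only a little higher, and the two values lie within the scatter of each other, so nothing separates them. Both compounds leave most of the cells in place at the concentration tested.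

Compound 3 `COc1cc(-c2cc(/C=C/C(=O)c3ccc(F)c(F)c3)[nH]n2)cc(OC)c1OC` is the next compound and has not yet been measured in this assay. It differs from compound 2 in one place:

3,4-difluorophenyl in place of 3,4-dichlorophenyl on a carbonyl carbon

Within the data shown here, no step between measured compounds exists that would show how such a change plays out in this assay. With compound 2 giving 92% and compound 1 giving 94%, both near the top of the scale, the expected step of a number 1 percentage points higher from compound 2 to compound 3 (within the scatter) is none beyond the scatter. Compound 3 is therefore estimated at 93%, within a range from 82% to 102%.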

Compound 3, a percentage reported as activity, at one concentration (the size of the read-out at that concentration, not a potency): 92%
Beside the measured number, compound 3's estimate is 1 percentage points above it; the range from low to high includes it.
By their numbers in this assay, from the lowest: compounds 2, 3 and 1 (each within the scatter of the next).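

Among these compounds, the swap of 3,4-dichlorophenyl for 3,4-difluorophenyl on a carbonyl carbon produces no change at the digits printed from compound 2 to compound 3 (within the scatter) in this assay and gives the first readable step at this position. At the single concentration tested, this position therefore tolerates the exchange of one halogen pair for the other without any shift in the read-out, but both compounds remain near the top of the scale, so the step cannot show whether the two groups would differ under conditions where a clear effect appears. Nothing available bears on why the two compounds read alike.

From the compounds shown here alone, whether a phenyl ring carrying a carboxylic acid, a nitrile or a trifluoromethyl group at this place would move the read-out remains open, as does the outcome with an unsubstituted phenyl ring. Going by these compounds, it also remains open whether compound 2 and compound 3 would separate at higher concentrations, with one of them showing a stronger effect there than the other, as the reading here comes from one concentration only.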